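Adding a (propargyloxy)methyl group to a cyclic sulfonamide nitrogen

The compounds below may be only part of what the source reports. "The series", "measured", "known", "first", "only" and "open" are said of these compounds alone.

Measured so far:
Compound 1, `O=C1c2ccccc2NS(=O)(=O)N1Cc1ccccc1`: > 50 ug/mL
Compound 2, `C#CCOCN1C(=O)c2ccccc2NS1(=O)=O`: 169 ug/mL

Compound 1 has the structure `O=C1c2ccccc2NS(=O)(=O)N1Cc1ccccc1`. In a functional assay on HEL cells (Homo sapiens) (on this read-out lower numbers stand for higher toxicity in this test and higher numbers for lower toxicity in this test), compound 1 gives > 50 ug/mL, which is a limit of the test and not a number, so compound 1 stands only as a limit on the scale shown (the limit of > 50 ug/mL in this assay, at which 1 of the 2 values shown sits). Compound 2, `C#CCOCN1C(=O)c2ccccc2NS1(=O)=O`, gives 169 ug/mL in this assay. The step that the limit leaves unreadable from compound 1 to compound 2 cannot be read in size, since one of its two ends is a limit.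

Compound 3, `C#CCOCN1c2ccccc2C(=O)N(Cc2ccccc2)S1(=O)=O`, has not yet been measured. It differs from compound 1 by (propargyloxy)methyl in place of hydrogen on a sulfonamide nitrogen in a ring. No measured step concerns this position, so nothing shown speaks directly to it; the only bearing comes from the low toxicity of both compound 1 and compound 2, whose values both sit in the weakly toxic part of the scale. Compound 3 is therefore expected to show no change beyond the scatter and to stay weakly toxic, with a step that the limit leaves unreadable from compound 1 to compound 3 as the expected step. Compound 3 is estimated at 110 ug/mL, within a range from 35 ug/mL to 300 ug/mL, in this assay.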

Compound 3, half-maximal cytotoxic concentration: > 50 ug/mL
Compound 3 was reported as a limit (the forecaster's own chance of this, stated with the estimate: 50%); the middle value is on the limit's open side.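

Compound 3 gives > 50 ug/mL in this assay as a limit of the test and not a number. Compound 1 also stands only as a limit, so the step from compound 1 to compound 3 cannot be read in size: the limit of > 50 ug/mL in this assay, at which 2 of the 3 values shown sit.

The compounds shown leave open whether (propargyloxy)methyl in place of hydrogen on this sulfonamide nitrogen changes the toxicity at all.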